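Capping a phenol hydroxy with a methyl group

This account rests on a few compounds, and the source may have more. Where it says the series, first, only, none or still open, it means among the compounds named here.

Of the compounds shown here, three sharing one core have been tested in a functional assay on aorta for antagonist activity at Alpha-1D adrenergic receptor (Rattus norvegicus); a lower number here means tighter binding, a higher number weaker binding. Compound 1 `Cc1ccccc1N1CCN(CCCNc2ncccc2C(=O)N(C)C)CC1` gives 10 nM. Compound 2 `CSc1ccccc1N1CCN(CCCNc2ncccc2C(=O)N(C)C)CC1` gives 31.6 nM, and compound 3 `COc1cc(O)ccc1N1CCN(CCCNc2ncccc2C(=O)N(C)C)CC1` gives 79.4 nM. Compound 3 thus has the highest number of the three; its steps from the others are a 7.9-fold higher number from compound 1 to compound 3 (0.90 log units; beyond the scatter) and a 2.5-fold higher number from compound 2 to compound 3 (0.40 log units; beyond the scatter), both beyond the scatter, so it is the weakest of the measured set.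

Compound 4 `COc1ccc(N2CCN(CCCNc3ncccc3C(=O)N(C)C)CC2)c(OC)c1` is compound 3 with one small change: methyl in place of hydrogen on an oxygen on an aromatic ring. Going by the values given here, none of the measured steps involves this kind of change. The steps of a 3.2-fold higher number from compound 1 to compound 2 (0.50 log units; beyond the scatter), a 7.9-fold higher number from compound 1 to compound 3 (0.90 log units; beyond the scatter) and a 2.5-fold higher number from compound 2 to compound 3 (0.40 log units; beyond the scatter) all concern a different part of the aryl ring or swap the whole ring at once, so they only show that alterations on this ring have moved the number by modest amounts in this assay. They give no direction for a hydroxy-to-methoxy exchange.

Among the compounds with values here, with no direct precedent, the expectation for compound 4 is a number close to that of compound 3, with the step of a 1.3-fold lower number from compound 3 to compound 4 (0.12 log units; within the scatter) treated as uncertain in direction and likely small. The estimate for compound 4 in this assay is 60 nM, within the range 18 nM to 200 nM.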

Compound 4, dissociation constant: 1000 nM
The estimate for compound 4 lay 17-fold (1.22 log units) below the measured number; measured number above the stated range.
By their numbers in this assay, from the lowest: compound 1; then compound 2; then compound 3; then compound 4.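

Capping the hydroxy of compound 3 as a methoxy group adds only one carbon, yet in this assay it produces a 13-fold higher number from compound 3 to compound 4 (1.10 log units; beyond the scatter) as a large step, so on this ring the hydroxy and the methoxy are far from interchangeable. Going by these compounds alone, this is the first view of a change made on that oxygen alone, and it shows that a single added methyl there can matter a great deal, at least in this pair. The result also places compound 4 at the weak end of the set, with a 32-fold higher number from compound 2 to compound 4 (1.50 log units; beyond the scatter) and a 100-fold higher number from compound 1 to compound 4 (2.00 log units; beyond the scatter) both printed as large steps, while no supporting measurement here accounts for the loss.

The compounds shown leave open how the number would respond if an ethoxy group, an amino group or a fluorine stood in place of this hydroxy, which would help separate the effect of capping the oxygen from that of replacing it. Also open, on these data alone, is whether adding a hydroxy and then capping it with methyl would play out the same way on the 2-methylphenyl ring of compound 1.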